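Swapping a Fluorophenyl for a Pyridinyl on the Amine Ring

A few compounds are considered here, and "the series" means these few. Any claim that something is new, unique, unknown or untested is made for them only; others in the source may bear on it.

Of the compounds shown here, three have been tested in a functional assay on MGC-803 cells (Homo sapiens) for antiproliferative activity, read by CCK-8 assay, with a stated time of 72 h, tested at 8 uM; on this read-out lower numbers stand for a weaker effect and higher numbers for a stronger effect at the one concentration tested. Compound 1 `Nc1ccccc1NC(=O)c1ccc(CSC(=S)N2CCN(c3ccc(F)cc3)CC2)cc1` gives 48.7%, the second highest of the three numbers. Compound 2 `CCN(Cc1ccncc1)C(=S)SCc1ccc(C(=O)Nc2ccccc2N)cc1` gives 85.2%, a number well above that of compound 1 and beyond the scatter. Compound 3 `Nc1ccccc1NC(=O)c1ccc(CSC(=S)N(Cc2ccccc2)Cc2ccccc2)cc1` gives 30.7%, which lies below compound 1, again beyond the scatter. No pair of these compounds differs in a single place, so no step is known.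

Compound 4 `Nc1ccccc1NC(=O)c1ccc(CSC(=S)N2CCN(c3ccncc3)CC2)cc1` differs from compound 1 in one place: pyridin-4-yl in place of 4-fluorophenyl on an amine nitrogen in a ring. Nothing measured isolates this exchange, since compound 2, which also carries a pyridin-4-yl, differs from compound 1 in several places at once. The expectation for compound 4 is therefore a step of a number 1.3 percentage points higher from compound 1 to compound 4 (within the scatter) that stays within the scatter, with no clear direction. In this assay compound 4 is estimated to give 50%, with a range from 32% to 68%.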

Compound 4, a percentage reported as inhibition, at one concentration (the size of the read-out at that concentration, not a potency): 87.1%
Estimate against measurement, compound 4: 37.1 percentage points below, and the stated range ends below it.
By their numbers in this assay, from the lowest: compound 3; then compound 1; then compounds 2 and 4 (each within the scatter of the next).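

In this assay, going by these compounds alone, pyridin-4-yl in place of 4-fluorophenyl on an amine nitrogen in a ring gives a number 38.4 percentage points higher from compound 1 to compound 4 (beyond the scatter), the first step that can be read. It shows that the read-out at this one concentration depends strongly on which aromatic ring sits at this position, three ring bonds from the ring nitrogen, and that the exchange brings a ring with one hydrogen-bond acceptor in place of a ring with none. Nothing at hand explains the size of this step.

The compounds shown leave open whether the step follows from the loss of fluorine or from the gain of the ring nitrogen. A plain phenyl or a pyridin-3-yl on the same nitrogen would speak to that question.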